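The compounds below may be only part of what the source reports. "The series", "measured", "known", "first", "only" and "open" are said of these compounds alone.

For the measured compounds named here, compound 3 `O=C(NC(=O)c1ccc(OCc2ccccc2F)cc1)Nc1ccc(Cl)c(-c2nc3ccccc3[nH]2)c1` gives 870 nM in a functional assay on MNK45 cells (Homo sapiens) for inhibition, read by MTT assay, with a stated time of 48 h (a higher number here means a weaker inhibitor, a lower number a stronger inhibitor), the lowest of the three numbers so far; compound 1 `Cc1ccc(NC(=O)NC(=O)c2ccc(OCc3ccccc3F)cc2)cc1-c1nc2ccccc2[nH]1` gives 1830 nM and compound 2 `Cc1ccc(COc2ccc(C(=O)NC(=O)Nc3ccc(C)c(-c4nc5ccccc5[nH]4)c3)cc2)cc1` gives 6360 nM. Compound 4 `Cc1ccc(COc2ccc(C(=O)NC(=O)Nc3ccc(Cl)c(-c4nc5ccccc5[nH]4)c3)cc2)cc1` differs from compound 3 by 4-methylphenyl in place of 2-fluorophenyl on a saturated chain carbon bound to an oxygen on an aromatic ring. Going by the values given here, the one measured step with this same change is a 3.5-fold higher number from compound 1 to compound 2 (0.54 log units; beyond the scatter), seen on the methyl-bearing pair, while the step from that pair to the chloro compound was a 2.1-fold lower number from compound 1 to compound 3 (0.32 log units; beyond the scatter). The same change is therefore expected to raise the number for compound 4 by a similar modest amount, beyond the scatter, with compound 4 estimated at 3000 nM with a range from 1200 nM to 8000 nM. That estimate means a step of a 3.4-fold higher number from compound 3 to compound 4 (0.54 log units; beyond the scatter) in this assay.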

Compound 4, half-maximal inhibitory concentration: 3190 nM
Compound 4: the middle estimate sits 1.1-fold (0.03 log units) below what was measured, and the stated range covers the measured number.
By their numbers in this assay, from the lowest: compound 3; then compounds 1, 4 and 2 (each within the scatter of the next, the first and the last beyond it).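

With the chloro group in place, 4-methylphenyl in place of 2-fluorophenyl gives a 3.7-fold higher number from compound 3 to compound 4 (0.56 log units; beyond the scatter) in this assay and so is no longer a single reading; its size holds on both cores: the same change on two cores in this assay, a 3.5-fold higher number (0.54 log units; beyond the scatter) from compound 1 to compound 2 and a 3.7-fold higher number (0.56 log units; beyond the scatter) from compound 3 to compound 4, 1.1-fold (0.02 log units) apart, within the scatter of two such steps. Chloro in place of methyl on an aromatic carbon, now read with the 4-methylphenyl group present, gives a 2.0-fold lower number from compound 2 to compound 4 (0.30 log units; within the scatter) and on its own does not clear the scatter, yet it agrees with the earlier step: the same change on two cores in this assay, a 2.1-fold lower number (0.32 log units; beyond the scatter) from compound 1 to compound 3 and a 2.0-fold lower number (0.30 log units; within the scatter) from compound 2 to compound 4, 1.1-fold (0.02 log units) apart, within the scatter of two such steps. Across these four compounds, the two changes therefore read as independent of each other.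

The change alters both the substituent and its ring position, and 4-fluorophenyl or 2-methylphenyl would separate the two. As far as these compounds go, an amine on the aromatic carbon now bearing chloro or methyl remains open.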